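The compounds below may be only part of what the source reports. "The series", "measured", "known", "first", "only" and "open" are said of these compounds alone.

Of the compounds shown here, three on a shared core have been measured in a functional assay on U-251 cells (Homo sapiens) for inhibition, read by sulforhodamine B assay, with a stated time of 72 h; on this read-out lower numbers stand for an effect already at smaller amounts and higher numbers for an effect only at larger amounts of compound. Compound 1 (`O=C(/C=C/c1ccc([N+](=O)[O-])o1)c1ccc(I)cc1`) gives 12500 nM and compound 2 (`O=C(/C=C/c1ccc([N+](=O)[O-])o1)c1ccc(N2CCCC2)cc1`) gives 35900 nM. Compound 3 (`O=C(/C=C/c1ccc([N+](=O)[O-])o1)c1ccc(N2CCCCC2)cc1`) stands only at a limit of the assay, > 50000 nM. Compound 4 (`O=C(/C=C/c1ccc(Cl)s1)c1ccc(N2CCCCC2)cc1`) carries 5-chlorothiophen-2-yl in place of 5-nitrofuran-2-yl on a double-bonded chain carbon bound to a double-bonded chain carbon. The modest 2.9-fold higher number from compound 1 to compound 2 (0.46 log units; beyond the scatter) and an at least 4.0-fold higher number from compound 1 to compound 3 (0.60 log units; beyond the scatter), and an at least 1.3-fold higher number from compound 2 to compound 3 (0.14 log units; that floor lies within the scatter), all change a group on an aromatic carbon, so none touches this place and they guide only by size. A modest move toward a lower number is therefore expected in this assay, with an at least 1.2-fold lower number from compound 3 to compound 4 (0.09 log units; that floor lies within the scatter) as the estimated step. For compound 4 the estimate is 40000 nM, within a range from 14000 nM to 80000 nM.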

Compound 4, half-maximal effective concentration: > 50000 nM
Compound 4: only a limit was reported; the forecaster's own chance of this, stated with the estimate: 50%; middle value at least 1.2-fold (0.09 log units) away from the limit.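

Among these compounds, compound 4 stands only at a limit of the assay, as compound 3 does, so no step between compound 3 and compound 4 can be read: the limit of > 50000 nM in this assay, at which 2 of the 4 values shown sit. The compounds shown leave open how 5-chlorothiophen-2-yl and 5-nitrofuran-2-yl compare at this place on the shared core.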